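Trimming the Allyl Chain on a Cyclopropane Amide

This account rests on a few compounds, and the source may have more. Where it says the series, first, only, none or still open, it means among the compounds named here.

Compound 1, `C=CCN(CC=C)C(=O)[C@@]1(c2ccsc2)C[C@H]1CN`: 8300 nM
Compound 2, `NC[C@@H]1C[C@@]1(C(=O)N1C=CCCC1)c1ccsc1`: > 10000 nM
Compound 3, `C=CCN(CCOC)C(=O)[C@@]1(c2ccsc2)C[C@H]1CN`: > 10000 nM

All three compounds were tested in an assay on HEK293 cells for inhibition of sodium-dependent dopamine transporter (Homo sapiens); a lower number here means a stronger inhibitor, a higher number a weaker inhibitor. Compound 1 gives 8300 nM there. For compound 2 the value > 10000 nM is a limit of the assay, not a number. For compound 3 the value > 10000 nM is likewise only a limit. Compound 3 therefore stands at the weak end of what was measured, and of the three values shown, (the limit of > 10000 nM in this assay, at which 2 of the 3 values shown sit).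

Compound 4, `COCCN(C)C(=O)[C@@]1(c2ccsc2)C[C@H]1CN`, differs from compound 3 by hydrogen in place of vinyl on a saturated chain carbon bound to an amide-type nitrogen. For the measured compounds named here, only one measured step touches the same carbon: an at least 1.2-fold higher number from compound 1 to compound 3 (0.08 log units; that floor lies within the scatter), a change that ended at the limit. Going by the values given here, no measured pair shows removal of a vinyl group on its own, and compound 1 and compound 2 share no single change with this step.

Compound 3 is already at a limit, and nothing measured points to a recovery from so small a trim. Compound 4 is thus expected to remain at a limit as well, the expected step being a step that the limit leaves unreadable from compound 3 to compound 4. Compound 4 is estimated at 15000 nM, with a range from 5000 nM to 50000 nM.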

Compound 4, half-maximal inhibitory concentration: > 10000 nM
Compound 4: only a limit was reported; the forecaster's own chance of this, stated with the estimate: 70%; the middle value does not contradict the limit.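

Compound 4 ends at a limit, as do compound 2 and compound 3, so the steps from compound 2 and from compound 3 to compound 4 cannot be read: the limit of > 10000 nM in this assay, at which 3 of the 4 values shown sit. The compounds shown leave open how weak compound 2, compound 3 and compound 4 actually are, and whether hydrogen in place of vinyl changes the number at all.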